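This account rests on a few compounds, and the source may have more. Where it says the series, first, only, none or still open, it means among the compounds named here.

Measured compounds:
- compound 1, `CN1CCC(n2cc(S(=O)(=O)c3cccc4ccccc34)c3ccccc32)C1`: 6 nM
- compound 2, `CCN1CCCC(n2cc(S(=O)(=O)c3cccc(F)c3)c3cc(OC)ccc32)C1`: 16 nM
- compound 3, `O=S(=O)(c1cccc(F)c1)c1cn(C2CCCNC2)c2ccc(F)cc12`: 4 nM

All three were tested in an assay on HeLa cells for displacement of a labelled ligand from 5-hydroxytryptamine receptor 6 (Homo sapiens), with a stated time of 2 h; on this read-out lower numbers stand for stronger inhibition and higher numbers for weaker inhibition. Among these numbers compound 1 stands second highest. Its nearest neighbour is compound 3, whose value lies within the usual scatter of compound 1, so the two cannot be told apart on this read-out. Compound 2 stands furthest away, with a number that is beyond the scatter above compound 1, which means compound 2 is the weaker binder of the pair.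

Compound 4, `O=S(=O)(c1cccc2ccccc12)c1cn(C2CCCNC2)c2ccccc12`, has not yet been measured. It differs from compound 1 in a single spot: piperidin-3-yl in place of 1-methylpyrrolidin-3-yl on an aromatic nitrogen. Both groups are built from the same count of atoms, but the ring grows from five to six members and gains a hydrogen-bond donor. Among the measured compounds shown here, no measured pair shows this exact change on its own. Compound 3, which carries the same piperidin-3-yl group on the shared core, gives 4 nM, a number within the scatter of compound 1, so no step beyond the scatter is expected for compound 4 in this assay, with at most a slight lean toward a lower number. The step from compound 1 to compound 4 is therefore estimated to be a 1.3-fold lower number from compound 1 to compound 4 (0.12 log units; within the scatter). For compound 4 the estimate is 4.5 nM, with a likely range from 1.5 nM to 13 nM.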

Compound 4, inhibition constant: 21 nM
Beside the measured number, compound 4's estimate is 4.7-fold (0.67 log units) below it; measured number outside the range, above it.
By their numbers in this assay, from the lowest: compounds 3 and 1 (each within the scatter of the next); then compounds 2 and 4 (each within the scatter of the next).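

Among the compounds shown here, replacing 1-methylpyrrolidin-3-yl with piperidin-3-yl on the aromatic nitrogen gives a 3.5-fold higher number from compound 1 to compound 4 (0.54 log units; beyond the scatter) in this assay, the first step at this position that can be read on its own. The step is modest, but it lies beyond the scatter, so this position is sensitive to more than the number and kind of atoms: both groups hold the same heavy atoms, yet they differ in how those atoms are joined. Nothing available here explains the loss of binding.

The change also bundles two differences, since the ring grows from five to six members and the group gains a hydrogen-bond donor, and the compounds shown cannot separate them. A pyrrolidin-3-yl group or a 1-methylpiperidin-3-yl group on the core of compound 1 would each alter only one of these features, and so would show whether ring size, the hydrogen on the ring nitrogen, or both together account for the step.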